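The compounds below may be only part of what the source reports. "The series", "measured", "known", "first", "only" and "open" are said of these compounds alone.

Working notes on the series: in a functional assay on B16-F10 cells (Mus musculus) for inhibition, with a stated time of 4 days (a lower number here means a stronger inhibitor, a higher number a weaker inhibitor), compound 1 (`COc1cc(O)c(C(=O)/C=C/c2cccc(O)c2)c(OC)c1`) gives 9900 nM and compound 2 (`COc1cc(O)c(C(=O)/C=C/c2ccc(O)cc2)c(OC)c1`) gives 6900 nM, so the two stand level within the scatter. Compound 3 (`COc1cccc(/C=C/C(=O)c2c(O)cc(OC)cc2OC)c1`) differs from compound 1 by methyl in place of hydrogen on an oxygen on an aromatic ring, hydroxy to methoxy. Among the measured compounds shown here, the only measured step, a 1.4-fold lower number from compound 1 to compound 2 (0.16 log units; within the scatter), swaps 3-hydroxyphenyl for 4-hydroxyphenyl and is a different change, so it bears only indirectly. For the measured compounds named here, no measured pair tests hydroxy to methoxy, so no shift beyond the scatter is expected in this assay. The expected step is a 1.1-fold higher number from compound 1 to compound 3 (0.05 log units; within the scatter). For compound 3 the estimated value is 11000 nM, with an expected range of 4500 nM to 27000 nM.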

Compound 3, half-maximal inhibitory concentration: 3100 nM
Compound 3: the middle estimate sits 3.5-fold (0.55 log units) above what was measured, and the stated range ends above it.
By their numbers in this assay, from the lowest: compound 3; then compounds 2 and 1 (each within the scatter of the next).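

In this assay the change of hydroxy to methoxy, methyl in place of hydrogen on an oxygen on an aromatic ring, gives a 3.2-fold lower number from compound 1 to compound 3 (0.50 log units; beyond the scatter) and moves the number beyond the scatter. The earlier swap of 3-hydroxyphenyl for 4-hydroxyphenyl did not do so, and the hydrogen on this oxygen is not needed for inhibition in compound 3. Nothing available explains the shift.

From the compounds shown here alone, whether a longer chain on this oxygen, such as ethoxy, or an amine in its place would go further remains open. So does whether the same change on compound 2 would give a similar step.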